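The compounds below may be only part of what the source reports. "The series", "measured", "known", "first", "only" and "open" are said of these compounds alone.

Compound 1, `CC[C@@H]1C[C@]1(NC(=O)[C@@H]1C[C@@H](Oc2ncc(OC)c3ccc(Cl)cc23)CN1C(=O)[C@@H](NC(=O)OC(C)(C)C)C(C)(C)C)C(=O)NS(=O)(=O)C1CC1`, gives 0.567 h in an ADME assay on liver (Homo sapiens) for metabolic stability, using microsomes; on this read-out lower numbers stand for a shorter-lived compound and higher numbers for a longer-lived compound.
Compound 2, `COc1cnc(O[C@@H]2C[C@@H](C(=O)N[C@]3(C(=O)NS(=O)(=O)C4CC4)C[C@H]3C(C)C)N(C(=O)[C@@H](NC(=O)OC(C)(C)C)C(C)(C)C)C2)c2cc(Cl)ccc12`, gives 1.38 h in this assay.
Compound 3, `COc1cnc(O[C@@H]2C[C@@H](C(=O)N[C@]3(C(=O)NS(=O)(=O)C4CC4)C[C@H]3C3CC3)N(C(=O)[C@@H](NC(=O)O[C@H](C)C(F)(F)F)C(C)(C)C)C2)c2cc(Cl)ccc12`, gives 2.12 h in this assay.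

Compound 2 and compound 3 differ in more than one place; the difference between the two cores is not broken down here. In this assay the step of a 2.4-fold lower number from compound 2 to compound 1 (0.39 log units; beyond the scatter) follows from hydrogen in place of methyl on a saturated chain carbon bound to a saturated chain carbon and a saturated ring carbon. Compound 4, `COc1cnc(O[C@@H]2C[C@@H](C(=O)N[C@]3(C(=O)NS(=O)(=O)C4CC4)C[C@H]3C3CC3)N(C(=O)[C@@H](NC(=O)O[C@H](C)C(F)(F)F)C(C)C)C2)c2cc(Cl)ccc12`, differs from compound 3 by hydrogen in place of methyl on a saturated chain carbon bound to three saturated chain carbons. This is the same kind of change as hydrogen in place of methyl on a saturated chain carbon bound to a saturated chain carbon and a saturated ring carbon, but the place differs: on a saturated chain carbon bound to three saturated chain carbons rather than bound to a saturated chain carbon and a saturated ring carbon. Because a 2.4-fold lower number from compound 2 to compound 1 (0.39 log units; beyond the scatter) was modest and the place is not the same, a smaller step of a 1.6-fold lower number from compound 3 to compound 4 (0.21 log units; within the scatter) is expected for compound 4. Compound 4 is estimated at 1.3 h in this assay, between 0.6 h and 2.6 h.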

Compound 4, half-life: 2.58 h
For compound 4 the middle estimate is 2.0-fold (0.30 log units) below the measured one; the measured number falls inside the stated range.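

In this assay the new step is a 1.2-fold higher number from compound 3 to compound 4 (0.09 log units; within the scatter) and so tert-butyl to isopropyl makes no readable difference on this core. Set beside the earlier step, hydrogen in place of methyl did not give the same result on the two cores: the same change on two cores in this assay, a 2.4-fold lower number (0.39 log units; beyond the scatter) from compound 2 to compound 1 and a 1.2-fold higher number (0.09 log units; within the scatter) from compound 3 to compound 4, 3.0-fold (0.47 log units) apart, beyond the scatter of two such steps. This does not show what separates the two results, as the change sits at a different place in each pair and the cores differ too, and two pairs give no rule for any further core.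

The compounds shown leave open how the same tert-butyl to isopropyl change would read on the core of compound 1. Also open, as far as these compounds go, is how a longer chain or a carboxylic acid in place of the isopropyl of compound 4 would read in this assay.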